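Swapping an Amide for a Dichlorophenyl Urea

The compounds below may be only part of what the source reports. "The series", "measured", "known", "first", "only" and "open" are said of these compounds alone.

Three measured compounds share one core and differ at a side chain. Compound 3 `COc1cc(-c2nn(-c3cccc(NC(=O)c4cccc(C(F)(F)F)c4)c3)cc2-c2ccncc2)ccc1Cl` carries an amide ending in a trifluoromethylphenyl group; in a functional assay on Hs-578T cells (Homo sapiens) for inhibition, read by sulforhodamine B assay, with a stated time of 48 h (on this read-out lower numbers stand for stronger inhibition of growth and higher numbers for weaker inhibition of growth), compound 3 gives 1070 nM. Compound 2 `COc1cc(-c2nn(-c3cccc(NC(=O)Nc4cc(C(F)(F)F)cc(C(F)(F)F)c4)c3)cc2-c2ccncc2)ccc1Cl` carries a urea instead and gives 1040 nM, which sits within the scatter of compound 3, so the two cannot be told apart. Compound 1 `O=C(Nc1cccc(-n2cc(-c3ccncc3)c(-c3ccc(Cl)c(O)c3)n2)c1)Nc1cccc(C(F)(F)F)c1` gives 3310 nM, a number beyond the scatter from compound 3. Among the three, compound 3 thus stands second highest, close to compound 2 and well apart from compound 1.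

Compound 4 `COc1cc(-c2nn(-c3cccc(NC(=O)Nc4ccc(Cl)c(Cl)c4)c3)cc2-c2ccncc2)ccc1Cl` has not yet been measured. It differs from compound 3 by (3,4-dichlorophenyl)amino in place of 3-(trifluoromethyl)phenyl on a carbonyl carbon. Since compound 2 with its urea gives 1040 nM, near compound 3, the urea itself seems to cost little on this core. Among the measured compounds shown here, no measured step describes the dichlorophenyl group, so the expected step from compound 3 to compound 4 is estimated as a 1.2-fold lower number from compound 3 to compound 4 (0.08 log units; within the scatter), likely inside the scatter. Compound 4 is therefore expected near 900 nM, with a range from 300 nM to 2700 nM.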

Compound 4, concentration for 50% growth inhibition: 1430 nM
Compound 4: the middle estimate sits 1.6-fold (0.20 log units) below what was measured; measured number inside the range.
By their numbers in this assay, from the lowest: compounds 2, 3 and 4 (each within the scatter of the next); then compound 1.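

In this assay the step is a 1.3-fold higher number from compound 3 to compound 4 (0.13 log units; within the scatter) for (3,4-dichlorophenyl)amino in place of 3-(trifluoromethyl)phenyl on a carbonyl carbon. This pair shows that this position accepts a change of both the link and the ring ending with no difference this read-out can resolve, even though the entering group brings a hydrogen-bond donor and two chlorines while the leaving group brings three fluorines. Nothing available explains why the number holds steady across this change.

The compounds shown leave open how far this tolerance reaches, since a piperidine or a carboxylic acid on the same carbonyl carbon could behave quite differently. Whether the pair also stays level in other cell lines is open as well.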